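Methyl in place of fluoro: the next step in the series

The source may report more compounds than this note shows. Statements on the series, on what has been measured and on what is new or still open speak of the compounds shown alone.

In a functional assay on HepG2 cells (Homo sapiens) for inhibition, read by MTT assay (on this read-out lower numbers stand for stronger inhibition of growth and higher numbers for weaker inhibition of growth), compound 1 `COc1cc2oc(-c3cccc(NC(=O)c4ccccc4Br)c3)cc(=O)c2c(OC)c1OC` gives 23100 nM, compound 2 `COc1cc2oc(-c3cccc(NC(=O)c4ccc(Cl)cc4)c3)cc(=O)c2c(OC)c1OC` gives 21300 nM, and compound 3 `COc1cc2oc(-c3cccc(NC(=O)c4ccc(F)cc4)c3)cc(=O)c2c(OC)c1OC` gives 47200 nM. Compound 3 thus stands highest of the three numbers: the nearer measured step is a 2.0-fold higher number from compound 1 to compound 3 (0.31 log units; beyond the scatter), the further one a 2.2-fold higher number from compound 2 to compound 3 (0.35 log units; beyond the scatter), while a 1.1-fold lower number from compound 1 to compound 2 (0.04 log units; within the scatter) stays within the scatter.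

Compound 4 `COc1cc2oc(-c3cccc(NC(=O)c4ccc(C)cc4)c3)cc(=O)c2c(OC)c1OC` differs from compound 3 by methyl in place of fluoro on an aromatic carbon, the exchange falling on the aromatic carbon that is para to a large group. Going by the values given here, the one measured step at this same place is a 2.2-fold higher number from compound 2 to compound 3 (0.35 log units; beyond the scatter), where fluoro took the place of chloro and the number rose beyond the scatter. Among the compounds with values here, no measured compound carries methyl at this place, so the direction for methyl rests on that single step only. Taking the fluoro away again is expected to lower the number in this assay by a modest amount, roughly back toward the level of compound 2. The estimate for compound 4 is 25000 nM, with a range of 10000 nM to 60000 nM. This corresponds to an expected step of a 1.9-fold lower number from compound 3 to compound 4 (0.28 log units; within the scatter).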

Compound 4, concentration for 50% growth inhibition: 9750 nM
Compound 4: the middle estimate sits 2.6-fold (0.41 log units) above what was measured; the whole stated range lies above it.
By their numbers in this assay, from the lowest: compound 4; then compounds 2 and 1 (each within the scatter of the next); then compound 3.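

In this assay, the aromatic carbon para to a large group now separates three substituents rather than two halogens: methyl gives a 4.8-fold lower number from compound 3 to compound 4 (0.68 log units; beyond the scatter) and a 2.2-fold lower number from compound 2 to compound 4 (0.34 log units; beyond the scatter), so among the groups tested here the number falls from fluoro through chloro to methyl. The change of aryl group also reads differently with methyl, since a 2.4-fold lower number from compound 1 to compound 4 (0.37 log units; beyond the scatter) lies beyond the scatter, whereas a 1.1-fold lower number from compound 1 to compound 2 (0.04 log units; within the scatter) stays within it. Nothing measured here accounts for the advantage of methyl over either halogen.

On these data alone, whether an ethyl group, a longer chain, a methoxy group or an amine at this carbon would lower the number further remains open. The size of the methyl step is also known only on the shared core of these compounds.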